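Swapping a Methoxy Ring for a Hydroxy Dimethyl Ring

A few compounds are considered here, and "the series" means these few. Any claim that something is new, unique, unknown or untested is made for them only; others in the source may bear on it.

Measured compounds in an assay on isolated protein for inhibition of protein kinase C theta type (Homo sapiens), read by TR-FRET, with a stated time of 2 h; on this read-out higher numbers stand for weaker inhibition and lower numbers for stronger inhibition:
compound 1 `CO[C@H]1CC[C@H](Nc2cc(NCc3cnccc3C(F)(F)F)ncc2C#N)CC1` gives 1100 nM
compound 2 `CN(C)C(=O)[C@H]1CC[C@@H](Nc2cc(NCc3cnccc3C(F)(F)F)ncc2C#N)CC1` gives 38 nM
compound 3 `N#Cc1cnc(NCc2ccccc2)cc1N[C@H]1CC[C@@H](O)CC1` gives 7000 nM

Compound 1 stands second highest of the three numbers in this assay. Compound 3 lies above it, a gap beyond the scatter, and compound 2 lies far below it, also beyond the scatter. Compound 4 `CC1(C)C[C@H](Nc2cc(NCc3cnccc3C(F)(F)F)ncc2C#N)CC[C@H]1O` has not been measured yet. It differs from compound 1 in one place: 4-hydroxy-3,3-dimethylcyclohexyl in place of 4-methoxycyclohexyl on a nitrogen on an aromatic ring. For the measured compounds named here, no measured pair shows this exact change, so its effect is open. A step toward a lower number that may not exceed the scatter is expected from compound 1 to compound 4, a 1.6-fold lower number from compound 1 to compound 4 (0.20 log units; within the scatter). Compound 4 is estimated at 700 nM, with a range from 200 nM to 3000 nM.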

Compound 4, half-maximal inhibitory concentration: 100 nM
Compound 4: middle estimate off by 7.0-fold (0.85 log units), on the high side; the measured number lies below the stated range.
By their numbers in this assay, from the lowest: compound 2; then compound 4; then compound 1; then compound 3.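

In this assay this position on the nitrogen proves sensitive: 4-hydroxy-3,3-dimethylcyclohexyl in place of 4-methoxycyclohexyl gives an 11-fold lower number from compound 1 to compound 4 (1.04 log units; beyond the scatter) with the rest of the molecule unchanged. The entering group has 1 hydrogen-bond donor and the leaving group has 0, yet that count alone does not explain the large step. Nothing measured here bears on the reason for it. On these data alone, the hydroxy and dimethyl parts change together, so their separate contributions remain open. Also open, as far as these compounds go, is how an amine or a carboxylic acid in place of the hydroxy would fare on this ring.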